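The source may report more compounds than this note shows. Statements on the series, on what has been measured and on what is new or still open speak of the compounds shown alone.

Working notes on the series, read in an ADME assay on the whole organism (strain CD-1) for metabolic stability, with Mus musculus as the target, at a dose of 3 mg/kg by the intravenous route; a lower number here means that the compound disappears faster, a higher number that the compound lasts longer. Compound 1 `CN(Cc1ccccc1OCCCCC(C)(C)C(=O)O)C(=O)c1ccc(-c2ccco2)cc1` gives 4.6 h, compound 2 `CN(Cc1ccccc1OCCC[C@@H]1C[C@@H]1C(=O)O)C(=O)c1ccc(-c2ccco2)cc1` gives 2.7 h, and compound 3 `CN(Cc1ccccc1OCCC[C@@H]1C[C@H]1C(=O)O)C(=O)c1ccc(-c2ccco2)cc1` gives 3.5 h. Compound 3 therefore stands within the scatter of both other compounds, and the three values read as one level.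

The next structure is compound 4 `CN(Cc1ccccc1OCCC/C=C/C(=O)O)C(=O)c1ccc(-c2ccco2)cc1`, and the change is 2-carboxyethenyl in place of 2-carboxycyclopropyl on a saturated chain carbon, three bonds along the chain from an oxygen on an aromatic ring. In words, this is 2-carboxyethenyl in place of 2-carboxycyclopropyl on a saturated chain carbon, three bonds along the chain from an oxygen on an aromatic ring.

Among the measured compounds shown here, three measured steps bear on this change. Putting 2-carboxycyclopropyl in place of 2-carboxy-2-methylpropyl gave a 1.7-fold lower number from compound 1 to compound 2 (0.23 log units; within the scatter) and a 1.3-fold lower number from compound 1 to compound 3 (0.12 log units; within the scatter). The third step, a 1.3-fold higher number from compound 2 to compound 3 (0.11 log units; within the scatter), goes with the fact that compounds 2 and 3 differ only in the configuration as drawn. For the measured compounds named here, all three stay within the scatter, but none of them tests 2-carboxyethenyl, which no measured compound carries, so the range has to stay wide.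

Anchored on compound 3 at 3.5 h, no step beyond the scatter is expected in this assay. The expected step reads a 1.2-fold lower number from compound 3 to compound 4 (0.08 log units; within the scatter). Compound 4 is estimated at 2.9 h, with an expected range of 1.3 h to 5.8 h.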

Compound 4, half-life: 1.9 h
The estimate for compound 4 lay 1.5-fold (0.18 log units) above the measured number; low and high end bracket the measured number.
By their numbers in this assay, from the lowest: compounds 4, 2, 3 and 1 (each within the scatter of the next, the first and the last beyond it).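

Among the compounds shown here, compound 4 gives the first step beyond the scatter, though a modest one, and it comes against the 2-carboxy-2-methylpropyl group of compound 1 (a 2.4-fold lower number from compound 1 to compound 4 (0.38 log units; beyond the scatter)). Against either cyclopropane compound, the open 2-carboxyethenyl group stays within the scatter in this assay (a 1.8-fold lower number from compound 3 to compound 4 (0.27 log units; within the scatter); a 1.4-fold lower number from compound 2 to compound 4 (0.15 log units; within the scatter)), so ring opening to the double bond shows no separate step of its own at this position. The same change is thus read twice, from two starting points that give the same reading within the scatter, with this qualification on the pair: the fact that compounds 2 and 3 differ only in the configuration as drawn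

The step from compound 1 replaces the two methyl groups and the saturated chain carbons in one move, so the compounds shown cannot assign it to either feature alone. Open too, as far as these compounds go, is how a fully saturated chain ending in the same carboxylic acid, the other double-bond geometry, or a tetrazole in place of the carboxylic acid would read at this position.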